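Cyclohexyl Amide in Place of Methoxybenzyl Amide

The source may hold more compounds than are shown below. What is called first, only, known or untested is meant among the compounds shown, and "the series" means these compounds.

Compound 1 `CCN(CC)C(=O)CN(c1cc(Cl)ccc1OC)S(=O)(=O)c1ccccc1`: in a functional assay on SH-SY5Y cells (Homo sapiens), read by MTT assay, with a stated time of 24 h (on this read-out lower numbers stand for an effect already at smaller amounts and higher numbers for an effect only at larger amounts of compound), compound 1 gives > 20000 nM, which is a limit of the assay and not a number.
Compound 2 `COc1ccc(CNC(=O)CN(c2cc(Cl)ccc2OC)S(=O)(=O)c2ccccc2)cc1`: in this assay compound 2 gives > 20000 nM, again a limit rather than a number.

Compound 2 therefore stands at the edge of what this assay reports. The step that the two limits leave unreadable from compound 1 to compound 2 is not readable, since both values sit at the limit of > 20000 nM in this assay, at which 2 of the 2 values shown sit. Compound 3 `COc1ccc(Cl)cc1N(CC(=O)NC1CCCCC1)S(=O)(=O)c1ccccc1` carries the change (cyclohexyl in place of 4-methoxybenzyl on an amide-type nitrogen). Within the data shown here, no measured step gives a size for this change, so no move beyond the scatter is expected in this assay. Compound 3 is estimated at 30000 nM, within a range from 8000 nM to 120000 nM. The expected step is a step that the limit leaves unreadable from compound 2 to compound 3.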

Compound 3, half-maximal effective concentration: 17600 nM
The estimate for compound 3 lay 1.7-fold (0.23 log units) above the measured number; measured number inside the range.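

Among these compounds, compound 3 is the first compound here to give a real number in this assay, so changes on this amide-type nitrogen can now be sized from a measured value: compound 3 gives 17600 nM. Cyclohexyl in place of 4-methoxybenzyl gives an at least 1.1-fold lower number from compound 2 to compound 3 (0.05 log units; that floor lies within the scatter), and cyclohexylamino in place of diethylamino gives an at least 1.1-fold lower number from compound 1 to compound 3 (0.05 log units; that floor lies within the scatter). These are only floors and the step between the two earlier compounds cannot be read, since those compounds sit at a limit of the assay: the limit of > 20000 nM in this assay, at which 2 of the 3 values shown sit.

On these data alone, what a cyclopentyl or phenyl group would give on this nitrogen remains open. So does the effect of an amine on the cyclohexyl ring.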